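From an iodo to two methyl groups on the aniline ring

A few compounds are considered here, and "the series" means these few. Any claim that something is new, unique, unknown or untested is made for them only; others in the source may bear on it.

Of the compounds shown here, three sharing one core have been measured in a functional assay on M21 cells (Homo sapiens) for antiproliferative activity, read by sulforhodamine B assay, with a stated time of 48 h; on this read-out higher numbers stand for weaker inhibition and lower numbers for stronger inhibition. Compound 1 `CCCCc1ccc(NS(=O)(=O)c2ccc(N3CCNC3=O)cc2)cc1` gives 450 nM. Compound 2 `O=C1NCCN1c1ccc(S(=O)(=O)Nc2ccc(I)cc2)cc1` gives 260 nM; the change a 1.7-fold lower number from compound 1 to compound 2 (0.24 log units; within the scatter) is within the scatter, so these two stand level. Compound 3 `CCCCCCCc1ccc(NS(=O)(=O)c2ccc(N3CCNC3=O)cc2)cc1` gives only a limit of the assay, > 1000 nM, and the limit of > 1000 nM in this assay, at which 1 of the 3 values shown sits, marks this as a limit rather than a number. The step of an at least 2.2-fold higher number from compound 1 to compound 3 (0.34 log units; beyond the scatter) and the step of an at least 3.8-fold higher number from compound 2 to compound 3 (0.58 log units; beyond the scatter) both fall beyond the scatter, and both show that the heptyl chain weakens inhibition.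

Compound 4 `Cc1ccc(NS(=O)(=O)c2ccc(N3CCNC3=O)cc2)c(C)c1` is compound 2 with one change: 2,4-dimethylphenyl in place of 4-iodophenyl on a sulfonamide nitrogen. Two small methyl groups thus replace the iodine. The step from compound 1 to compound 2 shows that a butyl chain and an iodine give similar numbers, while compound 3 shows that a much longer chain hurts. Two methyls are smaller than butyl, so in this assay compound 4 is expected to land near compounds 1 and 2, with a 1.7-fold higher number from compound 2 to compound 4 (0.24 log units; within the scatter) likely within the scatter. The estimate for compound 4 is 450 nM, with a range from 200 nM to 1200 nM.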

Compound 4, half-maximal inhibitory concentration: 150 nM
Estimate against measurement, compound 4: 3.0-fold (0.48 log units) above; measured number below the stated range.
By their numbers in this assay, from the lowest: compounds 4, 2 and 1 (each within the scatter of the next, the first and the last beyond it). At a limit, above all of these: compound 3.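

The iodine turns out not to be needed for a number of this size. With 2,4-dimethylphenyl in place of 4-iodophenyl on the sulfonamide nitrogen, the step in this assay (a 1.7-fold lower number from compound 2 to compound 4 (0.24 log units; within the scatter)) stays within the scatter, so the two compounds stand level. This position therefore accepts an all-carbon ring carrying two small groups as readily as one carrying a single iodine, and nothing measured here on these groups explains why.

Going by these compounds, it remains open whether both methyl groups are needed, since a ring with a single methyl would separate their contributions. Also unknown is how this position would respond to an amine or a carboxylic acid on the ring, groups quite unlike the iodo, alkyl and methyl groups seen so far.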